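The source may hold more compounds than are shown below. What is called first, only, known or untested is meant among the compounds shown, and "the series" means these compounds.

Compound 1 `Cn1c(=O)c(=O)n(C2CCCC2)c2nc(N/N=C/c3ccco3)ncc21` gives 72200 nM in a functional assay on PC-3 cells (Homo sapiens) for antiproliferative activity, read by MTT assay; a lower number here means a stronger inhibitor, a higher number a weaker inhibitor.
Compound 2 `Cn1c(=O)c(=O)n(C2CCCC2)c2nc(N/N=C/c3cccs3)ncc21` gives 75600 nM in this assay.
Compound 3 `Cn1c(=O)c(=O)n(C2CCCC2)c2nc(N/N=C/c3cccc(O)c3)ncc21` gives 36300 nM in this assay.

Compound 3 holds the lowest of the three numbers. Its step from compound 1 is a 2.0-fold lower number from compound 1 to compound 3 (0.30 log units; within the scatter), and its step from compound 2 is a 2.1-fold lower number from compound 2 to compound 3 (0.32 log units; beyond the scatter); only the second lies beyond the scatter, and even that one is modest. Compound 1 and compound 2 sit together, with a 1.0-fold higher number from compound 1 to compound 2 (0.02 log units; within the scatter) between them.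

Compound 4 `Cn1c(=O)c(=O)n(C2CCCC2)c2nc(N/N=C/c3cccc([N+](=O)[O-])c3)ncc21` is built from compound 3 by the change (nitro in place of hydroxy on an aromatic carbon). Going by the values given here, of the measured steps, those that bear on it are the swaps of the whole group on the carbon with a double bond to nitrogen, namely the step from compound 1 and the step from compound 2 to compound 3, both already given; none of the measured compounds carries a nitro group, so no step shows directly what a nitro in place of a hydroxy does. All three changes seen so far moved this assay only slightly, so compound 4 is expected to stay in the same region, with an estimated step of a 1.2-fold higher number from compound 3 to compound 4 (0.09 log units; within the scatter) that may well be within the scatter. Compound 4 is therefore estimated at 45000 nM, expected to lie between 18000 nM and 110000 nM.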

Compound 4, half-maximal inhibitory concentration: 20300 nM
Compound 4: middle estimate off by 2.2-fold (0.35 log units), on the high side; the measured number falls inside the stated range.
By their numbers in this assay, from the lowest: compounds 4, 3, 1 and 2 (each within the scatter of the next, the first and the last beyond it).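

In this assay, nitro in place of hydroxy on the aromatic carbon meta to a large group leaves the number within the scatter (a 1.8-fold lower number from compound 3 to compound 4 (0.25 log units; within the scatter)), so the hydrogen-bond donor of the hydroxy is not needed to reach this level, and the position also accepts a group of three heavy atoms. The 3-nitrophenyl group also separates from both heteroaryl groups, with modest steps beyond the scatter from thiophen-2-yl (a 3.7-fold lower number from compound 2 to compound 4 (0.57 log units; beyond the scatter)) and from furan-2-yl (a 3.6-fold lower number from compound 1 to compound 4 (0.55 log units; beyond the scatter)), whereas 3-hydroxyphenyl stayed within the scatter of furan-2-yl (a 2.0-fold lower number from compound 1 to compound 3 (0.30 log units; within the scatter)). Nothing available explains why these two substituents on the phenyl ring give the numbers they do.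

Going by these compounds, whether an amine, a carboxylic acid or a longer chain at this same carbon would keep the number at this level, or shift it further, remains open. The four compounds also share one core with the same substituents, so they leave open whether the small steps seen here would hold if the cyclopentyl group were replaced by another group.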